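Removing the Acyl Group from Compound 1

A few compounds are considered here, and "the series" means these few. Any claim that something is new, unique, unknown or untested is made for them only; others in the source may bear on it.

The compound of interest is compound 1 `O=C(Nc1cc(C(F)(F)F)cc(C(F)(F)F)c1)C1CCc2ccccc2N1C(=O)c1ccccc1Cl`, which in a functional assay on NUGC-3 cells (Homo sapiens) for cytotoxicity, read by sulforhodamine B assay, with a stated time of 72 h (on this read-out lower numbers stand for stronger inhibition of growth and higher numbers for weaker inhibition of growth), gives 1930 nM. Among the numbers shown it stands lowest: compound 2 `O=C(Nc1ccc(C(F)(F)F)cc1)C1CCc2ccccc2N1`, which carries a single trifluoromethyl group on its anilide and a free ring nitrogen, gives 18600 nM in this assay, a gap beyond the scatter. Compound 3 `CCCC(=O)N1c2ccccc2CCC1C(=O)Nc1ccccc1C(F)(F)F`, with a butanoyl group on the ring nitrogen, reaches only the limit of this assay at > 70000 nM; this is a limit and not a number (the limit of > 70000 nM in this assay, at which 1 of the 3 values shown sits).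

The step under consideration leads to compound 4 `O=C(Nc1cc(C(F)(F)F)cc(C(F)(F)F)c1)C1CCc2ccccc2N1`. The change is hydrogen in place of (2-chlorophenyl)carbonyl on a nitrogen on an aromatic ring in a ring, that is, the (2-chlorophenyl)carbonyl group leaves the nitrogen of the six-membered non-aromatic ring of the shared core and a hydrogen takes its place, while the bis(trifluoromethyl)anilide of compound 1 is kept. For the measured compounds named here, no pair of measured compounds differs in this one place alone, so the size of the step cannot be read directly. Compound 2, which also has a free ring nitrogen, sits well above compound 1, and on that basis a loss of potency is expected: the step from compound 1 to compound 4 is estimated at a 4.1-fold higher number from compound 1 to compound 4 (0.62 log units; beyond the scatter). Compound 4 is accordingly expected to give about 8000 nM in this assay, within a range from 2500 nM to 30000 nM.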

Compound 4, concentration for 50% growth inhibition: 8760 nM
The estimate for compound 4 lay 1.1-fold (0.04 log units) below the measured number; the range from low to high includes it.
By their numbers in this assay, from the lowest: compound 1; then compound 4; then compound 2. At a limit, above all of these: compound 3.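

For the compounds shown here, replacing the (2-chlorophenyl)carbonyl group on the ring nitrogen with hydrogen gives a 4.5-fold higher number from compound 1 to compound 4 (0.66 log units; beyond the scatter) in this assay, and this is the first reading of this position with the bis(trifluoromethyl)anilide and the rest of the molecule held the same. The step shows that the (2-chlorophenyl)carbonyl group goes with stronger inhibition of growth in this series, yet it is not needed for all of the activity, since compound 4, with its free ring nitrogen, still gives a measurable 8760 nM. The data shown give no cause for this step, as nothing measured here bears on why the number rises.

The compounds shown leave open which part of the departing group matters, the chlorine, the aromatic ring or the carbonyl, as compound 3 carries its butanoyl group together with a different anilide and so differs from compound 1 in more than one place. An unsubstituted benzoyl group, an acetyl group or a simple methyl group on that nitrogen, with the bis(trifluoromethyl)anilide kept, would separate these parts.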